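The source may hold more compounds than are shown below. What is called first, only, known or untested is meant among the compounds shown, and "the series" means these compounds.

Measured compounds:
- compound 1, `Nc1cc(N)c2nc(-c3ccccc3)c(NCc3ccc(Cl)c(Cl)c3)nc2c1`: 13500 nM
- compound 2, `CCOC(=O)[C@H](CCC(=O)O)NC(=O)c1ccc(Sc2nc3cc(N)cc(N)c3nc2-c2ccccc2)cc1`: 39800 nM
- compound 3, `COc1cc(CNc2nc3cc(N)cc(N)c3nc2-c2ccccc2)cc(OC)c1OC`: 14800 nM

In a functional assay on OVCAR-8 cells (Homo sapiens) for inhibition, read by sulforhodamine B assay, with a stated time of 48 h (on this read-out lower numbers stand for stronger inhibition of growth and higher numbers for weaker inhibition of growth), compound 1 gives the lowest of the three numbers. Compound 3 sits so close that the two cannot be told apart; compound 2 gives a higher number, and that gap lies beyond the scatter. No pair of these compounds differs in one place only, so no single step within the measured set can be read off.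

Among the measured compounds shown here, compound 4, `Nc1cc(N)c2nc(-c3ccccc3)c(NCc3ccc(F)cc3)nc2c1`, is the one unmeasured compound and differs from compound 1 in one place: 4-fluorophenyl in place of 3,4-dichlorophenyl on a saturated chain carbon bound to a nitrogen on an aromatic ring. Nothing measured in this series speaks to this particular change, so the expectation rests on compound 1 alone, with wide uncertainty. The step from compound 1 to compound 4 is expected to be modest, towards a somewhat higher number, and may well fall within the scatter: a 1.5-fold higher number from compound 1 to compound 4 (0.17 log units; within the scatter). For compound 4 in this assay the expected value is 20000 nM, with a range from 7000 nM to 55000 nM.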

Compound 4, concentration for total growth inhibition: 6030 nM
For compound 4 the middle estimate is 3.3-fold (0.52 log units) above the measured one; measured number below the stated range.
By their numbers in this assay, from the lowest: compound 4; then compounds 1 and 3 (each within the scatter of the next); then compound 2.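

In this assay, among the compounds shown here, the step of a 2.2-fold lower number from compound 1 to compound 4 (0.35 log units; beyond the scatter) is the first single change that can be read, and it lies beyond the scatter, though it is modest in size. This place on the saturated chain carbon bound to a nitrogen on an aromatic ring therefore responds to the substitution of the phenyl ring, and the two chlorines of the 3,4-dichlorobenzyl group are not required for growth inhibition on this core. Nothing available on these compounds accounts for the direction or size of this step.

Going by these compounds, it remains open whether the gain follows from losing the chlorines or from adding the fluorine, which an unsubstituted benzyl or a 4-chlorobenzyl group would separate. Also open, on these data alone, is how a longer chain between the aryl ring and the nitrogen would behave at this place.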